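This account rests on a few compounds, and the source may have more. Where it says the series, first, only, none or still open, it means among the compounds named here.

Working notes on the series. The shared core carries a carbonyl with a chain on it: compound 1 `CCCCCCC(=O)[C@@H]1COC(C)(C)N1C(=O)OC(C)(C)C` has hexyl on that carbonyl carbon, compound 2 `CCCCC#CC(=O)[C@@H]1COC(C)(C)N1C(=O)OC(C)(C)C` has hex-1-yn-1-yl there. In an assay on CHO cells for inhibition of sphingosine kinase 1 (Homo sapiens), tested at 10 uM (a higher number here means more inhibition at the concentration tested (going by the name of the read-out), a lower number less inhibition), compound 1 gives 4.71%, and compound 2 gives 9.08%. The only step measured so far, a number 4.4 percentage points higher from compound 1 to compound 2 (within the scatter), stays within the scatter, so on the numbers shown compound 2 stands level with compound 1; neither number is distinguishable from the other.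

Compound 3 `CCCCCCCCC#CC(=O)[C@@H]1COC(C)(C)N1C(=O)OC(C)(C)C` differs from compound 2 by butyl in place of hydrogen on a saturated chain carbon, four bonds along the chain from a triple-bonded carbon. Among the compounds with values here, no measured step bears directly on a change of this kind: the one step available, a number 4.4 percentage points higher from compound 1 to compound 2 (within the scatter), exchanges a saturated chain for a triple-bonded one of the same length and says nothing about extending a chain. Within the data shown here, with both measured numbers low and the only known step within the scatter, no step beyond the scatter is expected in this assay in either direction. Compound 3 is therefore estimated to give 12%, between 0% and 35%. The expected step is a number 2.9 percentage points higher from compound 2 to compound 3 (within the scatter).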

Compound 3, a percentage reported as inhibition, at one concentration (the size of the read-out at that concentration, not a potency): 15.2%
Compound 3: the middle estimate sits 3.2 percentage points below what was measured; the measured number falls inside the stated range.
By their numbers in this assay, from the lowest: compounds 1, 2 and 3 (each within the scatter of the next, the first and the last beyond it).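

Butyl in place of hydrogen on a saturated chain carbon, four bonds along the chain from a triple-bonded carbon, is the first change in the series that extends the chain rather than altering its bonds, and in this assay it gives a number 6.1 percentage points higher from compound 2 to compound 3 (within the scatter). This position therefore accepts butyl without a step beyond the scatter, and compound 3, at 15.2%, still gives a small read-out at a single concentration, which says nothing of potency. No available evidence bears on this result or connects it to any property of the butyl group.

On these data alone, it remains open whether a longer chain at this position, or a chain ending in an amine or a carboxylic acid, would give a step beyond the scatter in this assay. Within the data shown here, the effect of the triple bond at this greater chain length is also open, since that would need a fully saturated chain in place of the one in compound 3.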